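This account rests on a few compounds, and the source may have more. Where it says the series, first, only, none or still open, it means among the compounds named here.

Working notes on the shared core of compound 1 `C#CCSc1nnc(CC)n1N1C(=O)c2ccccc2C1=O`, compound 2 `CCc1nnc(SCC(=O)c2ccc(Cl)cc2)n1N1C(=O)c2ccccc2C1=O` and compound 3 `CCc1nnc(SC)n1N1C(=O)c2ccccc2C1=O`. In a functional assay on A549 cells (Homo sapiens) for cytotoxicity, read by MTT assay, with a stated time of 48 h (a higher number here means a weaker inhibitor, a lower number a stronger inhibitor), compound 1 gives only a limit, > 200000 nM. In this assay compound 2 likewise gives only a limit, > 200000 nM. In this assay compound 3 also gives only a limit, > 200000 nM. Compound 2 thus stands at the limit of > 200000 nM in this assay, at which 3 of the 3 values shown sit, and no number separates it from the other two. The three steps among them, a step that the two limits leave unreadable from compound 1 to compound 2, a step that the two limits leave unreadable from compound 1 to compound 3 and a step that the two limits leave unreadable from compound 2 to compound 3, are all of unreadable size.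

Compound 4 `COc1cc(-c2nnc(SCC(=O)c3ccc(Cl)cc3)n2N2C(=O)c3ccccc3C2=O)cc(OC)c1OC` differs from compound 2 by 3,4,5-trimethoxyphenyl in place of ethyl on an aromatic carbon. Among the measured compounds shown here, none of the measured steps touches this position, and none has a readable size, so they give no expectation of direction or size beyond the scatter. For the measured compounds named here, what the measured set shows is only that every value sits at the limit. Compound 4 is expected to give 150000 nM in this assay, with a range from 30000 nM to 400000 nM, most probably again reported as a limit. The estimated step is an at least 1.3-fold lower number from compound 2 to compound 4 (0.12 log units; that floor lies within the scatter), expected to stay within the scatter.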

Compound 4, half-maximal inhibitory concentration: 9030 nM
The estimate for compound 4 lay 17-fold (1.22 log units) above the measured number; measured number outside the range, below it.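

In this assay, among the compounds shown here, the aromatic carbon between two ring nitrogen atoms is the first place where a change can be read: 3,4,5-trimethoxyphenyl in place of ethyl gives an at least 22-fold lower number from compound 2 to compound 4 (1.34 log units; beyond the scatter). Compound 2 gives only a limit, > 200000 nM. The changes on the chain bound to sulfur among compound 1, compound 2 and compound 3 cannot be read, and only compound 4 has a number rather than a limit: the limit of > 200000 nM in this assay, at which 3 of the 4 values shown sit.

The compounds shown do not separate the part played by the aromatic ring from that of its methoxy groups, and they include neither plain phenyl nor a longer chain such as butyl on this carbon. Also open, going by these compounds, is whether 3,4,5-trimethoxyphenyl gives a number when combined with the groups on sulfur of compound 1 and compound 3.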